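Series notes: compound 4 from compound 3

The compounds below may be only part of what the source reports. "The series", "measured", "known", "first", "only" and "open" are said of these compounds alone.

Three compounds are in hand. In a functional assay on MCF7 cells (Homo sapiens) for cytotoxicity, read by MTT assay, with a stated time of 2 days, tested at 0.1 uM (on this read-out lower numbers stand for a stronger effect and higher numbers for a weaker effect at the one concentration tested), compound 1 `COc1ccc(-c2cc3cc(-c4ccccc4)cc(C(C)=O)c3[nH]2)cc1` gives 87%. Compound 2 `COc1ccc(-c2cc3cc(-c4ccc(F)cc4)cc(C(C)=O)c3[nH]2)cc1` gives 97.3% in this assay, a change described by a number 10.3 percentage points higher from compound 1 to compound 2 (beyond the scatter). Compound 3 `CC(=O)c1cc(/C=C/c2ccc(F)cc2)cc2cc(-c3ccc(F)cc3)[nH]c12` gives 98.8%, the highest of the three numbers; its gap to compound 2 is within the scatter, its gap to compound 1 beyond it. Compound 4 `COc1ccc(-c2cc3cc(/C=C/c4ccc(F)cc4)cc(C(C)=O)c3[nH]2)cc1` differs from compound 3 by methoxy in place of fluoro on an aromatic carbon. For the measured compounds named here, no measured step exchanges fluoro for methoxy; the single step in hand puts fluoro in place of hydrogen on an aromatic carbon and is modest. Since compounds 1, 2 and 3 all sit at high values, no step beyond the scatter is expected, a number 3.8 percentage points lower from compound 3 to compound 4 (within the scatter). Compound 4 is estimated at 95%, range 85% to 102%.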

Compound 4, a percentage reported as activity, at one concentration (the size of the read-out at that concentration, not a potency): 97.2%
Estimate against measurement, compound 4: 2.2 percentage points below; measured number inside the range.
By their numbers in this assay, from the lowest: compound 1; then compounds 4, 2 and 3 (each within the scatter of the next).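

In this assay, for the compounds shown here, the first exchange at this place, para to a large group, stays within the scatter: methoxy in place of fluoro (a number 1.6 percentage points lower from compound 3 to compound 4 (within the scatter)). 2-(4-fluorophenyl)ethenyl in place of 4-fluorophenyl also stays within it (a number 0.1 percentage points lower from compound 2 to compound 4 (within the scatter)), whereas 2-(4-fluorophenyl)ethenyl in place of phenyl goes beyond it (a number 10.2 percentage points higher from compound 1 to compound 4 (beyond the scatter)). Nothing available bears on the reason for these steps.

Going by these compounds, whether an amine or a carboxylic acid at this place would move the number beyond the scatter remains open.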